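The compounds below may be only part of what the source reports. "The series", "measured", "known", "first", "only" and "open" are said of these compounds alone.

Of the compounds shown here, three have been tested so far in an ADME assay on L6 cells (Rattus norvegicus) for cytotoxicity, read by resazurin assay, with a stated time of 72 h; a lower number here means a stronger inhibitor, a higher number a weaker inhibitor. Compound 1 `Clc1ccc(C(c2cncnc2)c2ccccc2Cl)cc1` gives > 100000 nM there, and that value is a limit of the assay and not a number. Compound 2 `Clc1ccc(C(c2ccc(Cl)cc2)c2cncnc2)cc1` gives 70100 nM and compound 3 `Clc1ccc(C(c2cccnc2)c2ccccc2Cl)cc1` gives 62300 nM in this assay, two values that lie within the scatter of each other. Compound 3 therefore stands with compound 2 on the numbers shown.

The step now in question leads to compound 4 `Clc1ccc(C(c2ccc(Cl)cc2)c2cccnc2)cc1` and is 4-chlorophenyl in place of 2-chlorophenyl on a saturated chain carbon bound to two aromatic carbons, with 4-chlorophenyl in place of 2-chlorophenyl on a saturated chain carbon bound to two aromatic carbons. The same exchange has been measured once, as an at least 1.4-fold lower number from compound 1 to compound 2 (0.15 log units; that floor lies within the scatter), and this is the step that bears most directly on it. Going by the values given here, the other measured step, an at least 1.6-fold lower number from compound 1 to compound 3 (0.20 log units; that floor lies within the scatter), concerns a different group and shows only that both measured changes start from a limit. On this single precedent, a small move toward a lower number in this assay is expected, one that may not clear the scatter. The expected change is a 1.5-fold lower number from compound 3 to compound 4 (0.17 log units; within the scatter) in this estimate. Compound 4 is estimated at 42000 nM, with an expected range from 15000 nM to 95000 nM.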

Compound 4, half-maximal inhibitory concentration: 84700 nM
Beside the measured number, compound 4's estimate is 2.0-fold (0.30 log units) below it; the range from low to high includes it.
By their numbers in this assay, from the lowest: compounds 3, 2 and 4 (each within the scatter of the next). At a limit, above all of these: compound 1.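

Going by these compounds alone, this result gives the first reading of 4-chlorophenyl in place of 2-chlorophenyl on a saturated chain carbon bound to two aromatic carbons that does not start from a limit: in this assay the change is a 1.4-fold higher number from compound 3 to compound 4 (0.13 log units; within the scatter). The exchange of pyrimidin-5-yl for pyridin-3-yl at the same place can now also be read between two numbers, as a 1.2-fold higher number from compound 2 to compound 4 (0.08 log units; within the scatter). Neither change therefore moves the number beyond the scatter wherever both ends are numbers, and the chlorophenyl exchange cannot be said to act differently on the two cores: the same change on two cores in this assay, an at least 1.4-fold lower number (0.15 log units; that floor lies within the scatter) from compound 1 to compound 2 and a 1.4-fold higher number (0.13 log units; within the scatter) from compound 3 to compound 4; the limit leaves it open whether they differ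

The same question stays open for the exchange of the nitrogen-containing ring: the same change on two cores in this assay, an at least 1.6-fold lower number (0.20 log units; that floor lies within the scatter) from compound 1 to compound 3 and a 1.2-fold higher number (0.08 log units; within the scatter) from compound 2 to compound 4; the limit leaves it open whether they differ Also open is how this assay would read with an amine or a carboxylic acid on the saturated chain carbon, as the compounds shown carry only chlorophenyl, pyridin-3-yl and pyrimidin-5-yl groups there.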